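Benzoyl for nitro on the shared core: cytotoxicity outlook

The source may report more compounds than this note shows. Statements on the series, on what has been measured and on what is new or still open speak of the compounds shown alone.

Three members of the series have been measured in an ADME assay on PC-3 cells (Homo sapiens) for cytotoxicity, read by WST assay, tested at 100 uM; on this read-out lower numbers stand for less inhibition and higher numbers for more inhibition at the one concentration tested (going by the name of the read-out). Compound 1 `O=C(Nc1cccc(-c2ccco2)c1)C1CCCN(C(=O)c2cc(C(F)(F)F)cc(C(F)(F)F)c2)C1` gives 0%. Compound 2 `Cc1nc(-c2cccc(C(=O)N3CCCC(C(=O)Nc4ccc(Cl)cc4)C3)c2)no1` gives 0%, and compound 3 `O=C(Nc1ccc(Cl)cc1)C1CCCN(C(=O)c2cccc([N+](=O)[O-])c2)C1` gives 0%. Compound 3 thus stands level with compound 1 and compound 2 at the digits shown, and the one step measured in a single place, no change at the digits printed from compound 2 to compound 3 (within the scatter), moved nothing beyond the scatter when nitro replaced 5-methyl-1,2,4-oxadiazol-3-yl on an aromatic carbon.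

Compound 4 `O=C(c1ccccc1)c1cccc(C(=O)N2CCCC(C(=O)Nc3ccc(Cl)cc3)C2)c1` is the next step from compound 3. The change is benzoyl in place of nitro on an aromatic carbon, sitting on an aromatic carbon of a six-membered aromatic ring of carbon only, meta to a large group. For the measured compounds named here, no measured step involves benzoyl itself. What bears on it is the exchange at the same kind of place, no change at the digits printed from compound 2 to compound 3 (within the scatter), which was flat, together with compound 1, whose different aryl amide and bis-trifluoromethyl benzoyl still left the read-out at 0%. With every measured member at the floor of this assay, the expected step is no change at the digits printed from compound 3 to compound 4 (within the scatter), none beyond the scatter. Compound 4 is accordingly estimated at 0%, within a range from 0% to 15%.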

Compound 4, a percentage reported as inhibition, at one concentration (the size of the read-out at that concentration, not a potency): 0%
For compound 4 middle estimate and measured number coincide at the digits printed; low and high end bracket the measured number.
By their numbers in this assay, from the lowest: compounds 1, 2, 3 and 4 (each within the scatter of the next).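

In this assay, the place on an aromatic carbon, meta to a large group, now carries a group with a ring: benzoyl brings 8 heavy atoms and a six-membered aromatic ring of carbon only, where nitro had 3 heavy atoms and no ring, and the result is no change at the digits printed from compound 3 to compound 4 (within the scatter). The comparison with the third group at this place gives no change at the digits printed from compound 2 to compound 4 (within the scatter), so nitro, benzoyl and 5-methyl-1,2,4-oxadiazol-3-yl all read alike here, and a much larger substituent with an added ring leaves the read-out where the smaller ones left it. No accompanying measurement offers an explanation for this flat result.

Going by these compounds, none of the three groups at this place separates from the others, so it remains open whether an amine or a carboxylic acid on the same aromatic carbon would give a different reading. Compound 1 differs from the others in more than one place, so the contribution of the aryl group on the amide stays unresolved, and a pyridine in its place would be one open case.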